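This account rests on a few compounds, and the source may have more. Where it says the series, first, only, none or still open, it means among the compounds named here.

Measured so far in a functional assay on the whole organism (heart) with Rattus norvegicus as the target; a higher number here means that more compound is needed for the effect, a lower number that less compound is needed:

- compound 1 `CC(=O)/C(=C\c1ccccc1)Oc1ccccc1OCC(C)N(C)C`: 0.9 mg/kg
- compound 2 `CC(=O)/C(=C\c1ccccc1)Oc1ccc(OCC(C)N(C)C)cc1`: 3 mg/kg

Compound 1 has the lower of the two numbers, so less of it is needed for the effect. The gap up to compound 2 lies beyond the usual scatter of repeated measurements. Two values are a thin basis for any trend.

The next compound to be tested is compound 3 `CC(=O)/C(=C\c1ccccc1)Oc1ccccc1OCCCN1CCCCC1`. It keeps the core of compound 1 but carries 2-(piperidin-1-yl)ethyl in place of 1-(dimethylamino)ethyl on a saturated chain carbon bound to an oxygen on an aromatic ring. Cut one bond further out, the same difference reads 2-(dimethylamino)propyl to 3-(piperidin-1-yl)propyl.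

Among the measured compounds shown here, no measured pair shows a change of this kind, so the size of this step in this assay is a judgement with wide uncertainty. A modest rise in the number is expected, possibly no larger than the scatter. The estimated step is a 1.7-fold higher number from compound 1 to compound 3 (0.22 log units; within the scatter). For compound 3 the expected value is 1.5 mg/kg, with an estimated range from 0.4 mg/kg to 5 mg/kg.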

Compound 3, dose for half-maximal effect: 0.2 mg/kg
Beside the measured number, compound 3's estimate is 7.5-fold (0.88 log units) above it, and the stated range ends above it.
By their numbers in this assay, from the lowest: compound 3; then compound 1; then compound 2.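

In this assay the group on the saturated chain carbon bound to an oxygen on an aromatic ring clearly matters, as putting 2-(piperidin-1-yl)ethyl in place of 1-(dimethylamino)ethyl gives a 4.5-fold lower number from compound 1 to compound 3 (0.65 log units; beyond the scatter) and so takes the number in the favourable direction. This one step shows that a larger group, with 8 heavy atoms instead of 5 and a six-membered non-aromatic ring, is accepted here without any loss in this whole-animal read-out. No measurement is available to explain the difference.

The step changes the form of the chain and the nitrogen substituents together, so the compounds shown cannot tell which of the two accounts for the lower number. A 2-(dimethylamino)ethyl group at this place would separate those two changes, while 2-(pyrrolidin-1-yl)ethyl and 2-(morpholin-4-yl)ethyl groups would test whether the result depends on the size of the ring or on a second ring hetero atom.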